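Swapping the aryl amide group in a growth-inhibition series

The compounds below may be only part of what the source reports. "The series", "measured", "known", "first", "only" and "open" are said of these compounds alone.

Values measured in a functional assay on T47D cells (Homo sapiens) for inhibition, read by CCK-8 assay, with a stated time of 72 h, tested at 1 uM (a lower number here means less inhibition of growth, a higher number more inhibition of growth at the concentration tested), are these
Compound 1 `CN(C)C(=O)c1cc2cnc(Nc3ccc(NC(=O)C4(C(=O)Nc5ccc(Cl)cc5)CC4)cc3)nc2n1C1CCCC1` gives 22.8%
Compound 2 `Cc1ccc(NC(=O)C2(C(=O)Nc3ccc(Nc4ncc5cc(C(=O)N(C)C)n(C6CCCC6)c5n4)cc3)CC2)cc1` gives 47.9%

Going by the values given here, compound 2 stands highest of the two compounds measured so far. Compound 3 `CN(C)C(=O)c1cc2cnc(Nc3ccc(NC(=O)C4(C(=O)Nc5cccc(C(F)(F)F)c5)CC4)cc3)nc2n1C1CCCC1` keeps the shared core and alters a single group. The change 3-(trifluoromethyl)phenyl in place of 4-methylphenyl on an amide-type nitrogen puts 3-(trifluoromethyl)phenyl in place of 4-methylphenyl on an amide-type nitrogen.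

Among the compounds with values here, only one measured step bears on this. It is a number 25.1 percentage points higher from compound 1 to compound 2 (beyond the scatter) and it came with methyl in place of chloro on an aromatic carbon of that same group. That step was modest but beyond the scatter, so a small edit to this group can clearly register. Within the data shown here, two compounds cannot establish a pattern, and no compound with trifluoromethyl has been measured. Still, the methyl compound is the higher of the pair, so losing that methyl is expected to cost something. In this assay the expected move is a number 11.9 percentage points lower from compound 2 to compound 3 (beyond the scatter) as an estimated modest fall no larger than the measured step. The estimate for compound 3 is 36% with an expected range from 18% to 58% in this read-out.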

Compound 3, percent growth inhibition at one concentration: 9.7%
For compound 3 the middle estimate is 26.3 percentage points above the measured one; measured number below the stated range.
By their numbers in this assay, from the lowest: compound 3; then compound 1; then compound 2.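

In this assay, the aryl group on the amide-type nitrogen can move the read-out much further than the earlier chloro-to-methyl edit suggested: replacing 4-methylphenyl with 3-(trifluoromethyl)phenyl gives a large change, a number 38.2 percentage points lower from compound 2 to compound 3 (beyond the scatter), where the earlier step was only modest. The same replacement starting from 4-chlorophenyl also gives a lower number, a number 13.1 percentage points lower from compound 1 to compound 3 (beyond the scatter), so compound 3 sits beyond the scatter below both earlier compounds and is the lowest of the three at the single concentration tested. Nothing shown here gives a measured reason for this fall.

The swap alters both the substituent and the number in the group's name, so these compounds cannot separate the effect of trifluoromethyl itself from the effect of where it sits on the ring. On these data alone, it also remains open how an unsubstituted phenyl, or an aryl ring carrying an amine or a carboxylic acid, would behave here, and three compounds are too few to set any rule for this position.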